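Removing the Acetyl Group: From Compound 1 to Compound 4

A few compounds are considered here, and "the series" means these few. Any claim that something is new, unique, unknown or untested is made for them only; others in the source may bear on it.

Of the compounds shown here, three sharing a common core have been measured in a functional assay on HCT-116 cells (Homo sapiens) for cytotoxicity, read by scintillation counting and thymidine incorporation, with a stated time of 72 h; a higher number here means a weaker inhibitor, a lower number a stronger inhibitor. Compound 1 `COc1cc(OC)cc(C(=CC#N)c2ccc(OC)c(NC(C)=O)c2)c1` gives 92 nM, the second highest of the three numbers. Compound 2 `CCOc1cc(C(=CC#N)c2ccc(OC)c(OC)c2)ccc1OC` gives 200 nM, a higher number than compound 1 and beyond the usual scatter. Compound 3 `CCOc1cc(C(=CC#N)c2ccc(N(C)C)cc2)ccc1OC` gives 31 nM, the lowest of the three and beyond the scatter from compound 1. Compound 4 `COc1cc(OC)cc(C(=CC#N)c2ccc(OC)c(N)c2)c1` has not yet been measured. It differs from compound 1 in one place: hydrogen in place of acetyl on a nitrogen on an aromatic ring. Among the compounds with values here, no measured pair shows this same change, so its effect is unknown; the expectation for this assay is a small step, if any, not beyond the scatter in either direction. Compound 4 is therefore expected to give about 80 nM, within a range from 25 nM to 250 nM, an expected step of a 1.2-fold lower number from compound 1 to compound 4 (0.06 log units; within the scatter).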

Compound 4, half-maximal inhibitory concentration: 1.4 nM
Estimate against measurement, compound 4: 57-fold (1.76 log units) above, outside the stated range (below it).
By their numbers in this assay, from the lowest: compound 4; then compound 3; then compound 1; then compound 2.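

Replacing the acetyl on this nitrogen with hydrogen, acetamido to amino, gives a 66-fold lower number from compound 1 to compound 4 (1.82 log units; beyond the scatter) and so counts as a large step. Within the data shown here, the earlier compounds held no pair differing in one place, so only this pair shows how strongly the cytotoxicity number depends on what sits on this nitrogen in the core of compound 1. Nothing available explains why the step is so large.

Open, on these data alone, is whether a formyl or a single methyl on this nitrogen would keep the low number, and what a hydroxyl in place of the amino group would give.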